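Shortening the Neopentyl Chain to Ethyl

This account rests on a few compounds, and the source may have more. Where it says the series, first, only, none or still open, it means among the compounds named here.

Compound 1 `CCOC(=O)/C(C)=C\c1ccc(Cc2cccnc2)n1-c1ccccc1`: 180000 nM
Compound 2 `CCOC(=O)/C(C)=C\c1ccc(Cc2cccnc2)n1CC(C)(C)C`: 57000 nM
Compound 3 `CCOC(=O)/C(C)=C\c1ccc(Cc2cccnc2)n1CC`: not yet measured

In a functional assay (aorta) for inhibition, with Homo sapiens as the target, using microsomes, in the presence of a further agent that is not named here (a higher number here means a weaker inhibitor, a lower number a stronger inhibitor), compound 2, at 57000 nM, holds the lower of the two numbers. Compound 3 carries methyl in place of tert-butyl on a saturated chain carbon bound to an aromatic nitrogen, which turns neopentyl into ethyl. Among the compounds with values here, one measured step bears on this only indirectly: a 3.2-fold lower number from compound 1 to compound 2 (0.50 log units; beyond the scatter), a modest change with neopentyl in place of phenyl on an aromatic nitrogen. Only a small step in this assay is therefore expected, perhaps toward a higher number. The expected change is a 1.6-fold higher number from compound 2 to compound 3 (0.20 log units; within the scatter). For compound 3 the estimate is 90000 nM, with an expected range of 30000 nM to 250000 nM.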

Compound 3, half-maximal inhibitory concentration: 14000 nM
For compound 3 the middle estimate is 6.4-fold (0.81 log units) above the measured one, and the stated range ends above it.
By their numbers in this assay, from the lowest: compound 3; then compound 2; then compound 1.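

In this assay, the number keeps falling as the group on the aromatic nitrogen changes, with a 4.1-fold lower number from compound 2 to compound 3 (0.61 log units; beyond the scatter) for the change from neopentyl to ethyl. Across the full series the change from phenyl to ethyl gives a 13-fold lower number from compound 1 to compound 3 (1.11 log units; beyond the scatter), the largest step so far, which places compound 3 lowest of the three. This position therefore accepts the shorter chain, and its number drops rather than rises.

On these data alone, whether methyl, a propyl chain or a chain ending in an amine on that nitrogen would lower the number further remains open. No measurement offered here explains the drop.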